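The source may report more compounds than this note shows. Statements on the series, on what has been measured and on what is new or still open speak of the compounds shown alone.

Measured in an ADME assay on MT4 cells (Homo sapiens) for cytotoxicity, read by MTT assay; a lower number here means that less compound is tolerated, a higher number that more compound is tolerated:
Compound 1, `O=C1c2ccccc2C(=O)N1CCOC(=S)N(C(=O)c1ccc([N+](=O)[O-])cc1)c1ccc(Cl)cc1`, gives only a limit of the assay, > 100000 nM.
Compound 2, `Cc1ccc(N(C(=O)c2ccc([N+](=O)[O-])cc2)C(=S)OCCN2C(=O)c3ccccc3C2=O)cc1`, gives 58000 nM.
Compound 3, `O=C1c2ccccc2C(=O)N1CCOC(=S)N(C(=O)c1cc([N+](=O)[O-])ccc1Cl)c1ccc(Cl)cc1`, gives 45000 nM.

Compound 2 holds the highest of the two numbers in this assay; compound 3 lies within the scatter of it, and the value of compound 1 is a limit. Compound 4, `Cc1ccc(N(C(=O)c2ccc(Cl)c(Cl)c2)C(=S)OCCN2C(=O)c3ccccc3C2=O)cc1`, differs from compound 2 by 3,4-dichlorophenyl in place of 4-nitrophenyl on a carbonyl carbon. Among the compounds with values here, the only measured step at the same carbonyl carbon is an at least 2.2-fold lower number from compound 1 to compound 3 (0.34 log units; beyond the scatter), which lowered the number. The step of an at least 1.7-fold lower number from compound 1 to compound 2 (0.23 log units; that floor lies within the scatter) changes another part of the molecule and does not bear on this one. A modest lowering in this assay is therefore expected, a 1.7-fold lower number from compound 2 to compound 4 (0.22 log units; within the scatter). Compound 4 is estimated at 35000 nM, within 15000 nM to 80000 nM.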

Compound 4, half-maximal cytotoxic concentration: 17000 nM
Compound 4: the middle estimate sits 2.1-fold (0.31 log units) above what was measured; low and high end bracket the measured number.
By their numbers in this assay, from the lowest: compound 4; then compounds 3 and 2 (each within the scatter of the next). At a limit, above all of these: compound 1.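

In this assay, 3,4-dichlorophenyl in place of 4-nitrophenyl on the carbonyl carbon gives a 3.4-fold lower number from compound 2 to compound 4 (0.53 log units; beyond the scatter), so this position moves the number beyond the scatter with both ends of the step measured. The earlier step at this carbon started from compound 1 (> 100000 nM), whose value is only a limit. Nothing at hand accounts for the size of the new step.

The change removes the nitro group and adds two chlorines at once, leaving open which of these goes with the lower number. Also open, as far as these compounds go, is how a phenyl carrying an amine or a carboxylic acid would read at this carbonyl carbon.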